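This account rests on a few compounds, and the source may have more. Where it says the series, first, only, none or still open, it means among the compounds named here.

In a functional assay on a cell-free system (plasma, Homo sapiens) for inhibition, with Plasma (Rattus norvegicus) as the target (a higher number here means a weaker inhibitor, a lower number a stronger inhibitor), compound 1 `CCCOc1ccc2c(N3CCNCC3)cc(=O)oc2c1C` gives 7770 nM and compound 2 `CSCOc1ccc2c(N3CCNCC3)cc(=O)oc2c1C` gives 3400 nM as the lower of the two numbers. Among the compounds with values here, the only measured step is a 2.3-fold lower number from compound 1 to compound 2 (0.36 log units; beyond the scatter) and it is modest, and it falls at the same place where the next compound differs. Compound 3 `Cc1c(OCC2CCCN(C)C2)ccc2c(N3CCNCC3)cc(=O)oc12` has not yet been measured. It carries 1-methylpiperidin-3-yl in place of methylsulfanyl on a saturated chain carbon bound to an oxygen on an aromatic ring, with 1-methylpiperidin-3-yl in place of methylsulfanyl on a saturated chain carbon bound to an oxygen on an aromatic ring as the counted difference. Within the data shown here, no measured compound has a ring at that place, so the data give no direction for this change. Among the measured compounds shown here, with only that one modest step as a guide, the expected step is a 1.1-fold lower number from compound 2 to compound 3 (0.05 log units; within the scatter) and no shift beyond the scatter is expected. For compound 3 the estimated value is 3000 nM and the expected range runs from 600 nM to 15000 nM with wide margins.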

Compound 3, half-maximal inhibitory concentration: 16400 nM
Estimate against measurement, compound 3: 5.5-fold (0.74 log units) below; the whole stated range lies below it.
By their numbers in this assay, from the lowest: compound 2; then compound 1; then compound 3.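

With 1-methylpiperidin-3-yl, this place on a saturated chain carbon bound to an oxygen on an aromatic ring takes its first ring, and the number moves up, with a 4.8-fold higher number from compound 2 to compound 3 (0.68 log units; beyond the scatter) and a 2.1-fold higher number from compound 1 to compound 3 (0.32 log units; beyond the scatter). Both open groups, methylsulfanyl and ethyl, therefore give lower numbers than this ring, and compound 3 is the weakest inhibitor of the three, so the position tolerates the larger group only at a cost in this series. Nothing available explains the rise.

The compounds shown do not separate the effect of the ring from that of its nitrogen, as only one ring stands at this place. A cyclohexyl group, a piperidin-3-yl group without the methyl on nitrogen, or a longer open chain would each bear on that question.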